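The source may hold more compounds than are shown below. What is called first, only, known or untested is meant among the compounds shown, and "the series" means these compounds.

Compounds 1 to 4 share one core: a six-membered ring with one oxygen that carries an amino group, two cyano groups and a 1H-indol-3-yl group, and whose single saturated ring carbon bears a changing aryl group. Compound 1 `N#CC1=C(N)OC(c2c[nH]c3ccccc23)=C(C#N)C1c1ccc2ccccc2c1` carries naphthalen-2-yl there. In a functional assay, tested at 50 ug/mL (a higher number here means a stronger effect of the compound at the concentration tested, a lower number a weaker effect), compound 1 gave "not active" (no number reported), so no number stands for it, only that it showed no effect. Compound 2 `COc1ccc(C2C(C#N)=C(N)OC(c3c[nH]c4ccccc34)=C2C#N)cc1` carries 4-methoxyphenyl and gives 12.4% in this assay. Compound 3 `N#CC1=C(N)OC(c2c[nH]c3ccccc23)=C(C#N)C1c1ccccc1Cl` carries 2-chlorophenyl and gives 8.5%. Among the compounds with values here, the one measured step, a number 3.9 percentage points lower from compound 2 to compound 3 (within the scatter), shows that swapping one small aryl group for another left the read-out within the scatter. Compound 4 `N#CC1=C(N)OC(c2c[nH]c3ccccc23)=C(C#N)C1c1ccc(F)cc1` carries the change (4-fluorophenyl in place of naphthalen-2-yl on a saturated ring carbon). Within the data shown here, no measured step matches this swap of a two-ring aryl for a single-ring one, so the measured compounds can only suggest that a single-ring aryl at this place gives a small read-out. Compound 4 is therefore expected to give about 10% in this assay, estimated between 0% and 25%.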

Compound 4, a percentage reported as activity, at one concentration (the size of the read-out at that concentration, not a potency): 8.4%
Compound 4: the middle estimate sits 1.6 percentage points above what was measured; the measured number falls inside the stated range.
By their numbers in this assay, from the lowest: compounds 4, 3 and 2 (each within the scatter of the next).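

Compound 4 brings a third single-ring aryl group to this saturated ring carbon, and the read-out does not separate it from the other two: there is a number 0.1 percentage points lower from compound 3 to compound 4 (within the scatter), and a number 4 percentage points lower from compound 2 to compound 4 (within the scatter). Thus 4-methoxyphenyl, 2-chlorophenyl and 4-fluorophenyl cannot be told apart in this assay, while the swap from naphthalen-2-yl pairs compound 1 at "not active" (no number reported) with compound 4 at 8.4%, a small but numerical read-out. No available evidence accounts for these results.

The compounds shown leave open whether any group at this carbon can raise the read-out well beyond these values. An aryl group carrying a carboxylic acid or an amine, or a saturated group such as cyclohexyl, might behave differently, and so might a change elsewhere on the shared core.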